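This account rests on a few compounds, and the source may have more. Where it says the series, first, only, none or still open, it means among the compounds named here.

Measured so far in a functional assay on the whole organism (strain albino) for inhibition, with Rattus norvegicus as the target, read by paw edema, with stated times of 30 min and 3 h, at a dose of 100 mg/kg by the oral route; on this read-out lower numbers stand for less inhibition and higher numbers for more inhibition at the one dose given (going by the name of the read-out):
compound 1, `Nc1ccc(C(=O)/C=C/c2ccc(Cl)cc2)cc1`: 60%
compound 2, `Nc1ccc(C(=O)/C=C/c2ccco2)cc1`: 42%
compound 3, `COc1ccc(/C=C/C(=O)c2ccc(NC(=O)C(C)Br)cc2)cc1`: 40%

Among these three, compound 1 stands highest; compound 2 sits below it by a gap beyond the scatter, and compound 3 sits further below by a gap that is also beyond the scatter. No two of the measured compounds differ in only one place, so no single change has a measured step of its own. Compound 3 carries a group on the nitrogen of its aromatic amine, but it also differs from compound 1 elsewhere, so its lower value cannot be tied to one change.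

Compound 4, `CC(O[N+](=O)[O-])C(=O)Nc1ccc(C(=O)/C=C/c2ccc(Cl)cc2)cc1`, is not yet measured. It differs from compound 1 by a group of 8 heavy atoms (3 carbon, 1 nitrogen, 4 oxygen; no ring) in place of a hydrogen atom, on a nitrogen on an aromatic ring. The two measured compounds that carry no such group, compounds 1 and 2, do not settle what this addition does. The step from compound 1 to compound 4 in this assay is expected to be small and downward or none beyond the scatter: a number 5 percentage points lower from compound 1 to compound 4 (within the scatter). Compound 4 is estimated to give about 55%, within a range from 40% to 70%.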

Compound 4, a percentage reported as inhibition, in the whole organism at one dose (the size of the read-out at that dose, not a potency): 62%
For compound 4 the middle estimate is 7 percentage points below the measured one; the range from low to high includes it.
By their numbers in this assay, from the lowest: compounds 3 and 2 (each within the scatter of the next); then compounds 1 and 4 (each within the scatter of the next).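

Placing this group of 8 heavy atoms on the nitrogen of the aromatic amine, in place of a hydrogen atom, gives a number 2 percentage points higher from compound 1 to compound 4 (within the scatter) in this assay. Going by these compounds alone, this is the first single change with a measured step, and it shows that the amine hydrogen of compound 1 can be replaced without a difference that can be told from the scatter. Nothing measured here explains this result.

Going by these compounds, it remains open whether a simpler group on this nitrogen, such as an acetyl group, would give a similar reading. The same addition to compound 2 could also read differently.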